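The compounds below may be only part of what the source reports. "The series", "measured", "known", "first", "only" and "open" are said of these compounds alone.

Compound 1 `FC(F)(F)c1cccc(N2CCN(c3ccc(-c4ncns4)nn3)CC2)c1` gives 70 nM
Compound 2 `CCc1nsc(-c2ccc(N3CCN(c4cccc(C(F)(F)F)c4)CC3)nn2)n1` gives 8 nM
Compound 3 `Cc1nsc(-c2ccc(N3CCN(c4cccc(C(F)(F)F)c4)CC3)nn2)n1` gives 0.3 nM

In a functional assay (aorta) for inhibition, with Rattus norvegicus as the target, with a stated time of 8 days (on this read-out lower numbers stand for stronger inhibition and higher numbers for weaker inhibition), compound 3 gives 0.3 nM as the lowest of the three numbers, and its steps to both other compounds lie beyond the scatter. Compound 4 `Cc1nsc(-c2ccc(N3CCN(c4cccc(C#N)c4)CC3)nn2)n1` differs from compound 3 in one place, with cyano in place of trifluoromethyl on an aromatic carbon. Going by the values given here, no measured step touches that place, so none of them shows the direction of this change. The measured steps (a 230-fold lower number from compound 1 to compound 3 (2.37 log units; beyond the scatter)) and (a 27-fold lower number from compound 2 to compound 3 (1.43 log units; beyond the scatter)) were large, and the step (an 8.8-fold lower number from compound 1 to compound 2 (0.94 log units; beyond the scatter)) was modest, so single changes among these compounds can move the number widely. Among the compounds with values here, with compound 3 at 0.3 nM as the lowest number so far, a higher number is expected for its untested replacement, though the size is uncertain. The expected change is a moderate one (a 10-fold higher number from compound 3 to compound 4 (1.00 log units; beyond the scatter)) beyond the scatter. For compound 4 the estimated value is 3 nM with an expected range (0.4 nM to 25 nM).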

Compound 4, half-maximal inhibitory concentration: 3 nM
Beside the measured number, compound 4's estimate shows no gap at the digits printed; measured number inside the range.
By their numbers in this assay, from the lowest: compound 3; then compound 4; then compound 2; then compound 1.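

In this assay, going by these compounds alone, the earlier steps all lay at another place in the molecule, so compound 4 gives the first reading of the place on the six-membered aromatic ring of carbon only. Cyano in place of trifluoromethyl there gives a 10-fold higher number from compound 3 to compound 4 (1.00 log units; beyond the scatter), which shows that this place also affects the number, although the step is smaller than the largest ones seen at the other place. Nothing in the available evidence explains this loss of strength.

On these data alone, whether a chlorine atom, a methoxy group or a carboxylic acid at this place would give a number closer to that of compound 3 or of compound 4 remains open. As far as these compounds go, it is also open whether the same replacement would have a similar effect with ethyl or hydrogen in place of the methyl.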